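The compounds below may be only part of what the source reports. "The series", "measured", "known", "first", "only" and "open" are said of these compounds alone.

Going by the values given here, in a functional assay (aorta) with Rattus norvegicus as the target (a higher number here means a more potent compound, by a factor of ten per unit of this negative logarithm, a lower number a less potent compound), compound 1 `CC1(C)C=C(n2ccccc2=O)c2cc(C(=O)c3ccco3)ccc2O1` gives 6.49, the lowest of the two numbers so far. Compound 2 `CC1(C)C=C(n2ccccc2=O)c2cc(C(=O)c3c(F)cccc3F)ccc2O1` gives 6.97, and the step of a number 0.48 log units higher from compound 1 to compound 2 (beyond the scatter) came with 2,6-difluorophenyl in place of furan-2-yl on a carbonyl carbon. Compound 3 `CC1(C)C=C(n2ccccc2=O)c2cc(-c3ccncc3)ccc2O1` carries pyridin-4-yl in place of (furan-2-yl)carbonyl on an aromatic carbon. Among the compounds with values here, only the step from compound 1 to compound 2 touches the same position, and it kept the carbonyl; no measured step covers its loss. The expected step is therefore a number 0.01 log units higher from compound 1 to compound 3 (within the scatter). Compound 3 is estimated at 6.5, between 5.8 and 7.2.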

Compound 3, logarithm of the reciprocal of the active concentration, log(1/C): 6.68
For compound 3 the middle estimate is 0.18 log units below the measured one, and the stated range covers the measured number.
By their numbers in this assay, from the lowest: compounds 1, 3 and 2 (each within the scatter of the next, the first and the last beyond it).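

Swapping (furan-2-yl)carbonyl for pyridin-4-yl removes the carbonyl from this aromatic carbon, and in this assay the outcome is a number 0.19 log units higher from compound 1 to compound 3 (within the scatter). At this position, the carbonyl is therefore not required for a number in this range, at least when pyridin-4-yl takes its place. No measurement shown here offers an explanation for this result.

Going by these compounds, whether the ring nitrogen of pyridin-4-yl matters remains open, and a plain phenyl on the same carbon would address that. On these data alone, how a nitrile or an amine would compare there also remains open.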